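This account rests on a few compounds, and the source may have more. Where it says the series, first, only, none or still open, it means among the compounds named here.

Measured in this series:
compound 1 `Cc1cc(Cl)c(S(C)(=O)=O)cc1C(=O)N=C(N)N` — 25 nM
compound 2 `Cc1cc(OC2CCCCC2)c(S(C)(=O)=O)cc1C(=O)N=C(N)N` — 37 nM
compound 3 `Cc1cc(Oc2ccccc2Cl)c(S(C)(=O)=O)cc1C(=O)N=C(N)N` — 14 nM

In a functional assay for inhibition of sodium/hydrogen exchanger (Oryctolagus cuniculus) (a lower number here means a stronger inhibitor, a higher number a weaker inhibitor), compound 3 gives the lowest of the three numbers. Its separation from compound 1 is small: a 1.8-fold lower number from compound 1 to compound 3 (0.25 log units; within the scatter) lies within the scatter. Against compound 2 the gap is real but modest: a 2.6-fold lower number from compound 2 to compound 3 (0.42 log units; beyond the scatter). The remaining pair shows a 1.5-fold higher number from compound 1 to compound 2 (0.17 log units; within the scatter), again within the scatter, so compound 1 and compound 2 cannot be ranked against each other.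

Compound 4 `Cc1cc(Oc2ccc(Cl)cc2)c(S(C)(=O)=O)cc1C(=O)N=C(N)N` is built from compound 3 by a rearrangement of the same atoms: 4-chlorophenyl in place of 2-chlorophenyl on an oxygen on an aromatic ring. Of the measured steps none changes where the chlorine sits on the phenoxy group; the steps into compound 3 from compound 1 and from compound 2 concern the introduction of the whole 2-chlorophenoxy group and so bear only indirectly on this change. Within the data shown here, with no direct precedent, a step of no more than the usual scatter is expected in either direction, a 1.2-fold higher number from compound 3 to compound 4 (0.08 log units; within the scatter). Compound 4 is therefore estimated at 17 nM, with a range of 6 nM to 50 nM.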

Compound 4, half-maximal inhibitory concentration: 13 nM
The estimate for compound 4 lay 1.3-fold (0.12 log units) above the measured number; measured number inside the range.
By their numbers in this assay, from the lowest: compounds 4, 3, 1 and 2 (each within the scatter of the next, the first and the last beyond it).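

In this assay, among these compounds, the change from 2-chlorophenoxy to 4-chlorophenoxy gives a 1.1-fold lower number from compound 3 to compound 4 (0.03 log units; within the scatter) and is the first direct reading of where the chlorine sits on this group, which here does not separate the two compounds. Against the cyclohexyl ether, the 4-chlorophenoxy group gives a 2.8-fold lower number from compound 2 to compound 4 (0.45 log units; beyond the scatter) and so, like 2-chlorophenoxy, stands beyond the scatter, whereas the exchange for chloro on the aromatic carbon gives a 1.9-fold lower number from compound 1 to compound 4 (0.28 log units; within the scatter) and shows no separation. No measured evidence bears on why the two chlorine placements read alike.

Going by these compounds, whether a phenoxy group without chlorine, or one carrying a methoxy group or a carboxylic acid in place of the chlorine, would read the same remains open. Also open, on these data alone, is whether an amine could stand in place of the oxygen link.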